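The source may hold more compounds than are shown below. What is called first, only, known or untested is meant among the compounds shown, and "the series" means these compounds.

In an ADME assay on SH-SY5Y cells (Homo sapiens) for cytotoxicity, read by MTT assay, with a stated time of 48 h (on this read-out lower numbers stand for an effect already at smaller amounts and higher numbers for an effect only at larger amounts of compound), compound 1 `O=C(NCCCCCCCn1cc(-c2cccnc2)nn1)c1ccccc1-c1c[nH]nn1` gives 86.5 nM. Compound 2 `O=C(NCCCCCCCn1cc(-c2cccnc2)nn1)c1ccccc1-n1cc(CN2CCC(O)CC2)nn1` gives > 10000 nM in this assay, and this is a limit of the assay, not a number. Its true position is therefore unknown, and any step starting from it is only approximate. Of the two measured compounds, compound 2 is the one at that limit: the limit of > 10000 nM in this assay, at which 1 of the 2 values shown sits.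

Compound 3 `O=C(NCCCCCCCn1cc(-c2cccnc2)nn1)c1ccccc1-n1cc(CN2CCCC2)nn1` keeps the rest of compound 2 and changes one group: pyrrolidin-1-yl in place of 4-hydroxypiperidin-1-yl on a saturated chain carbon bound to an aromatic carbon. Pyrrolidin-1-yl stands in place of 4-hydroxypiperidin-1-yl on a saturated chain carbon bound to an aromatic carbon. For the measured compounds named here, no measured pair differs in one place, so the size of this step has no direct precedent.

Compound 1, at 86.5 nM, shows that low values do occur among these compounds, which supports an expectation of movement toward lower numbers. The expected change is moderate, an at least 3.3-fold lower number from compound 2 to compound 3 (0.52 log units; beyond the scatter), and a result still at the limit would not be surprising. For compound 3 the estimated value is 3000 nM, with an expected range of 300 nM to 10000 nM.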

Compound 3, half-maximal effective concentration: > 10000 nM
Compound 3: no number, only a limit (the forecaster's own chance of this, stated with the estimate: 35%); middle value at least 3.3-fold (0.52 log units) away from the limit.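

In this assay compound 3 gives > 10000 nM, which is a limit of the assay and not a number, and the step between the two limits cannot be read. For the compounds shown here, the one readable step is 4-((pyrrolidin-1-yl)methyl)-1H-1,2,3-triazol-1-yl in place of 1H-1,2,3-triazol-4-yl on an aromatic carbon, with an at least 110-fold higher number from compound 1 to compound 3 (2.06 log units; beyond the scatter), a large change that places a second substituted compound far from the low value of the core of compound 1. Two different rings on the saturated chain carbon bound to an aromatic carbon, 4-hydroxypiperidin-1-yl and pyrrolidin-1-yl, now end at the same limit: the limit of > 10000 nM in this assay, at which 2 of the 3 values shown sit.

Any difference between these two rings remains hidden at that limit, and the step from compound 1 changes both the attachment of the triazole and the presence of the substituent in one move. A plain 1H-1,2,3-triazol-1-yl on the same aromatic carbon would separate those two changes, and a small open-chain amine such as dimethylamino on the methyl carbon would test whether any amine at this place reads below the limit in this assay.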